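This account rests on a few compounds, and the source may have more. Where it says the series, first, only, none or still open, it means among the compounds named here.

Measured so far:
- compound 1, `COc1cc(-c2cc(/C=C/C(=O)c3ccc(Cl)c(Cl)c3)[nH]n2)cc(OC)c1OC`: 9%
- compound 2, `COc1ccc(C(=O)/C=C/c2cc(-c3cc(OC)c(OC)c(OC)c3)n[nH]2)cc1OC`: -73%

Within the data shown here, in a functional assay on IGROV-1 cells (Homo sapiens) for cytotoxicity, read by sulforhodamine B assay, with a stated time of 48 h, tested at 100 uM (on this read-out higher numbers stand for a weaker effect at the one concentration tested and lower numbers for a stronger effect), compound 2 stands as the lower of the two numbers; compound 1 sits a long way above it, the only measured step being a number 82 percentage points lower from compound 1 to compound 2 (beyond the scatter). Among the measured compounds shown here, that step replaces the whole aryl group on the carbonyl carbon and is the sole guide to how this part of the shared core answers to change.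

Compound 3, `COc1cc(C(=O)/C=C/c2cc(-c3cc(OC)c(OC)c(OC)c3)n[nH]2)cc(OC)c1OC`, is not yet measured. It differs from compound 2 by methoxy in place of hydrogen on an aromatic carbon. For the measured compounds named here, the one known step concerns the same aryl group but swaps chlorines for methoxy groups, so it does not tell how a third methoxy entering ortho to a methoxy group and meta to a large group will read; it only shows the ring is sensitive. A small step, within or near the scatter, is expected: a number 8 percentage points higher from compound 2 to compound 3 (within the scatter). Compound 3 is therefore estimated at -65%, within -100% to -15%.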

Compound 3, a percentage reported as activity, at one concentration (the size of the read-out at that concentration, not a potency): -97%
Beside the measured number, compound 3's estimate is 32 percentage points above it; the measured number falls inside the stated range.
By their numbers in this assay, from the lowest: compound 3; then compound 2; then compound 1.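

In this assay, methoxy entering ortho to a methoxy group and meta to a large group gives a number 24 percentage points lower from compound 2 to compound 3 (beyond the scatter). This ring therefore answers to one added methoxy group, and not only to the exchange of the whole aryl group seen in a number 82 percentage points lower from compound 1 to compound 2 (beyond the scatter). Both steps on this aryl group run towards lower numbers, the first large and the second modest.

The compounds shown leave open whether methoxy itself matters at this place, or whether a hydroxyl, an amine or a longer chain such as ethoxy would read the same. From the compounds shown here alone, all three compounds also share the rest of the core, so how that part answers to change remains open. No measurement at hand gives a reason for the size of this step.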